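The source may hold more compounds than are shown below. What is called first, only, known or untested is meant among the compounds shown, and "the series" means these compounds.

Compound 3 `Cc1c(C(C)OC(=O)Nc2ccccc2)oc2nc(-c3ccc(F)cc3)nn12` in a functional assay on CHO cells for antagonist activity at metabotropic glutamate receptor 5 (Homo sapiens), read by calcium flux (on this read-out lower numbers stand for stronger inhibition and higher numbers for weaker inhibition), gives 10 nM. On this number compound 3 stands level with compound 2 `Cc1c(C(C)OC(=O)Nc2ccccc2)oc2nc(Cl)nn12`, which in this assay gives 10 nM; the two share the lowest numbers of the three compounds, while the parent compound 1 `Cc1c(C(C)OC(=O)Nc2ccccc2)oc2ncnn12` in this assay gives 63.1 nM. Compound 4 `Cc1c(C(C)OC(=O)Nc2ccccc2)oc2nc(C(F)(F)F)nn12` differs from compound 3 in one place: trifluoromethyl in place of 4-fluorophenyl on an aromatic carbon.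

For the measured compounds named here, three measured steps bear on this change. Going by the values given here, the step of a 6.3-fold lower number from compound 1 to compound 2 (0.80 log units; beyond the scatter) and the step of a 6.3-fold lower number from compound 1 to compound 3 (0.80 log units; beyond the scatter) show that putting either chloro or 4-fluorophenyl onto this aromatic carbon lowers the number by the same amount, and the step of no change at the digits printed from compound 2 to compound 3 (within the scatter) shows that exchanging the one group for the other leaves the number where it is. Since a chloro and a 4-fluorophenyl at this carbon give the same result in this assay, a trifluoromethyl at the same carbon is expected to behave alike, and the change from compound 3 to compound 4 is expected to stay within the scatter, a 1.2-fold higher number from compound 3 to compound 4 (0.08 log units; within the scatter). Compound 4 is therefore estimated at 12 nM in this assay, with a range from 4 nM to 40 nM.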

Compound 4, half-maximal inhibitory concentration: 39.8 nM
Compound 4: the middle estimate sits 3.3-fold (0.52 log units) below what was measured; the range from low to high includes it.
By their numbers in this assay, from the lowest: compounds 2 and 3 (each within the scatter of the next); then compounds 4 and 1 (each within the scatter of the next).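

In this assay, for the compounds shown here, the aromatic carbon between two ring nitrogen atoms proves more selective than the earlier compounds suggested: a 4.0-fold higher number from compound 3 to compound 4 (0.60 log units; beyond the scatter) and a 4.0-fold higher number from compound 2 to compound 4 (0.60 log units; beyond the scatter) show that the match between chloro and 4-fluorophenyl does not extend to trifluoromethyl. Against the parent, a 1.6-fold lower number from compound 1 to compound 4 (0.20 log units; within the scatter) means that trifluoromethyl in place of hydrogen has no effect that can be told from the scatter, so the gain seen with chloro in compound 2 and with 4-fluorophenyl in compound 3 is not a general result of filling this carbon, and compound 4 goes against that pattern. The data shown include no measured finding that accounts for this difference between the groups.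

The compounds shown leave open where methyl, methoxy, nitrile or an amine at this carbon would fall relative to chloro and trifluoromethyl. They also leave open whether a phenyl without its fluorine would match 4-fluorophenyl, and whether the gap between trifluoromethyl and the other two groups would persist with a different group in place of the phenyl on the carbamate nitrogen.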